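Replacing 4-ethylphenyl with 3-fluorophenyl on the shared core

The source may report more compounds than this note shows. Statements on the series, on what has been measured and on what is new or still open speak of the compounds shown alone.

Compound 1, `CCCc1ccc(NC2=CC(=O)c3c(nc4n3[C@H]3OC[C@@H](O)[C@H]3OC4)C2=O)cc1`: > 4000 nM
Compound 2, `O=C1C(N2CCCCC2)=CC(=O)c2c1nc1n2[C@H]2OC[C@@H](O)[C@H]2OC1`: > 8000 nM
Compound 3, `CCc1ccc(NC2=CC(=O)c3c(nc4n3[C@H]3OC[C@@H](O)[C@H]3OC4)C2=O)cc1`: > 4000 nM

In a functional assay on ECa-109 cells for inhibition, with ECa-109 cell line (Homo sapiens) as the target, read by sulforhodamine B assay (on this read-out lower numbers stand for stronger inhibition and higher numbers for weaker inhibition), compound 3 reaches only a limit, > 4000 nM. Compound 1 also stands at a limit in this assay, > 4000 nM. Compound 2 likewise gives a limit in this assay, > 8000 nM. The two measured steps that lead into compound 3, a step that the two limits leave unreadable from compound 1 to compound 3 and a step that the two limits leave unreadable from compound 2 to compound 3, therefore cannot be sized, as the limit of > 4000 nM in this assay, at which 2 of the 3 values shown sit, and the limit of > 8000 nM in this assay, at which 1 of the 3 values shown sits, show: every value here is a limit and no number.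

Compound 4, `O=C1C(Nc2cccc(F)c2)=CC(=O)c2c1nc1n2[C@H]2OC[C@@H](O)[C@H]2OC1`, differs from compound 3 by 3-fluorophenyl in place of 4-ethylphenyl on an amine nitrogen. Going by the values given here, no measured step bears on this change, and none of the three compounds gives a number that could anchor a direction. Compound 4 is therefore expected to stay at the limit as well, with an estimate of 6000 nM in this assay, somewhere between 1500 nM and 25000 nM. The expected step, a step that the limit leaves unreadable from compound 3 to compound 4, is no more than a guess at no change beyond the scatter.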

Compound 4, half-maximal inhibitory concentration: 2370 nM
Compound 4: the middle estimate sits 2.5-fold (0.40 log units) above what was measured; low and high end bracket the measured number.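

Going by these compounds alone, with compound 4, a change on this amine nitrogen gives the first actual number in this assay, so the series now has a reference point that is not a limit. Moving from piperidin-1-yl to (3-fluorophenyl)amino gives an at least 3.3-fold lower number from compound 2 to compound 4 (0.52 log units; beyond the scatter), which shows that this exchange on the double-bonded ring carbon lowers the number on this read-out. By contrast, 3-fluorophenyl in place of the alkylphenyl groups gives an at least 1.6-fold lower number from compound 3 to compound 4 (0.22 log units; that floor lies within the scatter) and an at least 1.6-fold lower number from compound 1 to compound 4 (0.22 log units; that floor lies within the scatter), so neither step yet establishes a real gain.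

Compound 3 stands at a limit, so the true size of its step remains open: the limit of > 4000 nM in this assay, at which 2 of the 4 values shown sit.
Going by these compounds, what the fluorine itself contributes also remains open, and a plain phenyl or a 3-chlorophenyl group on the same amine nitrogen would bear on that question.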